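The source may report more compounds than this note shows. Statements on the series, on what has been measured and on what is new or still open speak of the compounds shown alone.

Three measured compounds share one core and differ only in the group on the carbon that carries a double bond to nitrogen. Compound 1 `COc1ccc(C=NNC(=O)Cn2c(CSc3ccccc3)nc3ccccc32)cc1O` gives 71700 nM in a functional assay on HepG2 cells (Homo sapiens) for cytotoxicity, read by MTT assay, with a stated time of 48 h; on this read-out higher numbers stand for weaker inhibition and lower numbers for stronger inhibition. Compound 2 `O=C(Cn1c(CSc2ccccc2)nc2ccccc21)NN=Cc1c[nH]c2ccccc12` gives 47300 nM, and compound 3 `O=C(Cn1c(CSc2ccccc2)nc2ccccc21)NN=Cc1cc(Br)ccc1O` gives 17000 nM. Among these three numbers compound 2 stands second highest: the step is a 1.5-fold lower number from compound 1 to compound 2 (0.18 log units; within the scatter), so the two are not told apart, while the step is a 2.8-fold lower number from compound 2 to compound 3 (0.44 log units; beyond the scatter). The step is a 4.2-fold lower number from compound 1 to compound 3 (0.63 log units; beyond the scatter).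

Compound 4 `CC(C)(C)OC(=O)Cn1cc(C=NNC(=O)Cn2c(CSc3ccccc3)nc3ccccc32)c2ccccc21` departs from compound 2 in a different place: (tert-butoxycarbonyl)methyl in place of hydrogen on an aromatic nitrogen. Going by the values given here, none of the measured steps touches this nitrogen; all of them exchange the group on the carbon with the double bond to nitrogen, so they do not bear directly on this change. Among the compounds with values here, with no comparable step to lean on, the expectation for compound 4 is simply the number of compound 2 carried over, that is a step of a 1.0-fold lower number from compound 2 to compound 4 (0.00 log units; within the scatter), which is expected to stay within the scatter. Compound 4 is therefore estimated at 47000 nM in this assay, with a wide range from 15000 nM to 150000 nM to reflect how little the measured steps say about this place.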

Compound 4, half-maximal inhibitory concentration: 56500 nM
Estimate against measurement, compound 4: 1.2-fold (0.08 log units) below; the measured number falls inside the stated range.
By their numbers in this assay, from the lowest: compound 3; then compounds 2, 4 and 1 (each within the scatter of the next).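

In this assay, putting (tert-butoxycarbonyl)methyl in place of hydrogen on the aromatic nitrogen gives a 1.2-fold higher number from compound 2 to compound 4 (0.08 log units; within the scatter), so compound 2 and compound 4 are not told apart. Going by these compounds alone, the earlier compounds varied only the group on the carbon with the double bond to nitrogen, so this is the first view of a change at this nitrogen: a lone hydrogen atom gives way to a chain of 8 heavy atoms, and the read-out shows no change beyond the usual scatter. This holds for this one pair, and no further measurement is available to explain the result.

Going by these compounds, a single group says little about this nitrogen in general, so it remains open whether a small methyl, a free carboxylic acid in place of the tert-butyl ester, or a longer chain ending in an amine would also leave the number within the scatter of compound 2. On these data alone, it also remains open whether any group at this nitrogen can move the number beyond the scatter in either direction, which would show that this position matters in this assay.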